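This account rests on a few compounds, and the source may have more. Where it says the series, first, only, none or still open, it means among the compounds named here.

Measured so far:
compound 1 `CC1=C(C(=O)OC(C)(C)C)C(c2ccoc2)NC(=O)N1` — 11%
compound 2 `CC1=C(C(=O)OC(C)(C)C)C(c2ccsc2)NC(=O)N1` — 15%

Both numbers come from an assay on membranes from CHO cells for displacement of a labelled ligand from adenosine receptor A1 (Homo sapiens), read by scintillation counting, with a stated time of 60 min, tested at 1 uM; on this read-out higher numbers stand for more inhibition at the one concentration tested (going by the name of the read-out) and lower numbers for less inhibition. Compound 2 and compound 1 lie within the scatter of each other, as the step of a number 4 percentage points higher from compound 1 to compound 2 (within the scatter) shows. Compound 3 `CCNC(=O)C1=C(C)NC(=O)NC1c1ccsc1` is not yet measured. It differs from compound 2 in ethylamino in place of tert-butoxy on a carbonyl carbon. Among the compounds with values here, the one measured step concerns the ring on the saturated ring carbon, not the carbonyl carbon, so no measured step bears on this change. The expected step is a number 3 percentage points lower from compound 2 to compound 3 (within the scatter), estimated to stay within the usual scatter. For compound 3 the estimate is 12%, with a range from 2% to 28%.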

Compound 3, a percentage reported as inhibition, at one concentration (the size of the read-out at that concentration, not a potency): 3%
Compound 3: the middle estimate sits 9 percentage points above what was measured; the range from low to high includes it.
By their numbers in this assay, from the lowest: compounds 3, 1 and 2 (each within the scatter of the next, the first and the last beyond it).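

Working from this assay, ethylamino in place of tert-butoxy on a carbonyl carbon gives a number 12 percentage points lower from compound 2 to compound 3 (beyond the scatter), so this position, unlike the ring on the saturated ring carbon, carries a measured change beyond the scatter. The size of the step is modest. Nothing available gives a reason for this step.

Still open, from the compounds shown here alone, is whether the step tracks the loss of tert-butoxy or the entry of ethylamino. Also open, going by these compounds, is how a methoxy group, a longer amine chain or a carboxylic acid at this carbonyl carbon would compare with compound 2.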